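Exchanging the aromatic group on a chain at a limit

The source may hold more compounds than are shown below. What is called first, only, known or untested is meant among the compounds shown, and "the series" means these compounds.

In a functional assay on MCF7 cells (Homo sapiens) for inhibition, read by MTT assay, with a stated time of 72 h (on this read-out higher numbers stand for weaker inhibition and lower numbers for stronger inhibition), compound 1 `Nc1ncnc2c1c(-c1cnc3[nH]ccc3c1)nn2CCCCCCCCC(=O)NO` gives a measured number of 24700 nM as its result. Compound 2 `Nc1ncnc2c1c(-c1cnc3[nH]ccc3c1)nn2CCCCCC(=O)NO` has only a limit, which is > 150000 nM and not a measured number. Compound 3 `Nc1nc2cc(-c3nn(CCCCCCCCCC(=O)NO)c4ncnc(N)c34)ccc2o1` also has only a limit, which is > 50000 nM and likewise not a measured number.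

Within the data shown here, compound 4 `Nc1ncnc2c1c(-c1cnc3[nH]ccc3c1)nn2CCCCCCCCCC(=O)NO` keeps the chain of compound 3 and differs from it in one place: a group of 9 heavy atoms (7 carbon, 2 nitrogen; one five-membered aromatic ring with 1 hetero atom, one six-membered aromatic ring with 1 hetero atom) in place of a group of 10 heavy atoms (7 carbon, 2 nitrogen, 1 oxygen; one five-membered aromatic ring with 2 hetero atoms, one six-membered aromatic ring of carbon only), on an aromatic carbon and the incoming group is the one already carried by compounds 1 and 2. Among the measured compounds shown here, no measured step makes this exchange directly. The nearest evidence is an at least 6.0-fold higher number from compound 1 to compound 2 (0.78 log units; beyond the scatter) and that step alters the chain while this aromatic group stays in place, so it bears on the exchange only indirectly. It does show that a compound with the incoming group can give a number, since compound 1 reads 24700 nM in this assay as noted.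

A lower number than the limit of compound 3 is therefore expected. The estimated change is an at least 2.7-fold lower number from compound 3 to compound 4 (0.44 log units; beyond the scatter) and its size remains uncertain. For compound 4 the expected value is 18000 nM with an estimated range from 5000 nM to 60000 nM as its bounds.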

Compound 4, half-maximal inhibitory concentration: 23200 nM
The estimate for compound 4 lay 1.3-fold (0.11 log units) below the measured number; measured number inside the range.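

Placed on the aromatic carbon of the five-membered ring, next to the ring nitrogen, the incoming group takes the place of 2-amino-1,3-benzoxazol-5-yl and gives an at least 2.1-fold lower number from compound 3 to compound 4 (0.33 log units; beyond the scatter) in this assay, so this exchange on an unchanged chain turns a limit into a measured number. Compound 3 has only a limit, which makes this step a bound rather than a full size: the limit of > 50000 nM in this assay, at which 1 of the 4 values shown sits. With the incoming group kept, the chain of compound 4 gives an at least 6.4-fold lower number from compound 2 to compound 4 (0.81 log units; beyond the scatter), while a 1.1-fold lower number from compound 1 to compound 4 (0.03 log units; within the scatter), so the chains of compound 1 and compound 4 cannot be told apart on this read-out, and both stand apart from the shorter chain of compound 2.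

From the compounds shown here alone, compound 2 also has only a limit, so the full size of its step stays open: the limit of > 150000 nM in this assay, at which 1 of the 4 values shown sits. The compounds shown also leave open how a plain phenyl group or an unfused pyridine ring would read on this aromatic carbon, and whether a longer chain or a carboxylic acid in place of the hydroxycarbamoyl end would keep a measurable number.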